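From Methyl to Isopropyl on a Ring Nitrogen

A few compounds are considered here, and "the series" means these few. Any claim that something is new, unique, unknown or untested is made for them only; others in the source may bear on it.

- compound 1 `CCN1C(=O)CN(Cc2ccc(-c3cccc(CN4CCCCC4)n3)cc2)C1=O` in a physicochemical assay for lipophilicity; a higher number here means a more lipophilic compound, a lower number a more polar compound: 1.7
- compound 2 `CN1C(=O)CN(Cc2ccc(-c3cccc(CN4CCCCC4)n3)cc2)C1=O` in this assay: 1.3

Within the data shown here, only two compounds have been measured so far, and compound 2 holds the lower number at 1.3. The next compound to be measured is compound 3 `CC(C)N1C(=O)CN(Cc2ccc(-c3cccc(CN4CCCCC4)n3)cc2)C1=O`, which has the same core as compound 2. It carries isopropyl in place of methyl on an amide-type nitrogen in a ring.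

Just one measured step bears on this change. It is a number 0.40 log units lower from compound 1 to compound 2 (beyond the scatter), a modest step beyond the scatter, and it occurs on the same nitrogen, where compound 1 carries ethyl and compound 2 carries methyl. Read backwards, this step shows the number in this assay rising as the chain on that nitrogen gains carbon. Isopropyl holds more carbon than ethyl, so a rise somewhat larger than that single step is a reasonable expectation, though one step is thin evidence for its size.

The expected change is a number 0.70 log units higher from compound 2 to compound 3 (beyond the scatter), upward and beyond the scatter. The estimate for compound 3 is 2, with an expected range from 1.7 to 2.4.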

Compound 3, distribution coefficient: 2.2
Compound 3: the middle estimate sits 0.20 log units below what was measured, within the range that was stated.
By their numbers in this assay, from the lowest: compound 2; then compound 1; then compound 3.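

Isopropyl in place of methyl on the amide-type nitrogen gives a number 0.90 log units higher from compound 2 to compound 3 (beyond the scatter) and isopropyl in place of ethyl on that same nitrogen gives a number 0.50 log units higher from compound 1 to compound 3 (beyond the scatter) in this one position. Where a single step once gave only one comparison, the three groups now fall into a full order in this assay, running from methyl through ethyl to isopropyl, with every gap beyond the scatter and none of the three compounds going against that order. Nothing measured here gives a reason for this rise in the number across the three groups.

The compounds shown leave open whether a straight propyl chain would give a number close to that of the branched isopropyl group, so chain length and branching cannot yet be told apart at this nitrogen. Also open, on these data alone, is how far the order extends to a longer chain such as butyl, and whether it says anything about a different kind of group on this nitrogen, such as an amine or a carboxylic acid.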